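A few compounds are considered here, and "the series" means these few. Any claim that something is new, unique, unknown or untested is made for them only; others in the source may bear on it.

Three compounds have been examined in a functional assay on Bel-7402 cells (Homo sapiens) for inhibition, read by sulforhodamine B assay, with a stated time of 72 h, tested at 10 uM; on this read-out lower numbers stand for less inhibition and higher numbers for more inhibition at the one concentration tested (going by the name of the read-out). Compound 1, `C[C@H](Nc1nc(N)nc(N)c1C#N)c1nn(-c2cccc(S(C)(=O)=O)c2)c2cc(F)ccc12`, gives 14%. Compound 2, `C[C@H](Nc1ncnc2[nH]cnc12)c1nn(-c2cccnc2)c2cc(Cl)ccc12`, gives 17%, and compound 3, `C[C@H](Nc1ncnc2[nH]cnc12)c1nn(-c2cccnc2)c2cc(F)ccc12`, gives 8%. Compound 2 and compound 3 share one core and differ in only one place: chloro in place of fluoro on an aromatic carbon. This change gives a number 9 percentage points higher from compound 3 to compound 2 (within the scatter), so the two numbers cannot be told apart with confidence. Compound 1 carries a different core; how the core of compound 1 differs from that of compound 3 is not broken down here, and the values of compound 1 and compound 3 lie close to one another.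

Compound 4, `C[C@H](Nc1nc(N)nc(N)c1C#N)c1nn(-c2cccc(S(C)(=O)=O)c2)c2cc(Cl)ccc12`, has not yet been measured. It stands to compound 1 as compound 2 stands to compound 3: chloro in place of fluoro on an aromatic carbon. The change itself and the surroundings of the place where it sits are the same in both pairs, so the step already seen is the closest guide available. Because that change gave a number 9 percentage points higher from compound 3 to compound 2 (within the scatter), a step of similar small size is expected here, and the expected step in this assay is a number 6 percentage points higher from compound 1 to compound 4 (within the scatter). Compound 4 is therefore estimated at 20%, with a likely range from 8% to 33%. Whether the measured number lands inside that range remains to be seen.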

Compound 4, a percentage reported as inhibition, at one concentration (the size of the read-out at that concentration, not a potency): 47%
Beside the measured number, compound 4's estimate is 27 percentage points below it; the measured number lies above the stated range.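

In this assay, chloro in place of fluoro on the aromatic carbon of the core of compound 1 gives a number 33 percentage points higher from compound 1 to compound 4 (beyond the scatter). So in this series, the effect of this one small change does not carry over at the same size from one core to the other, and a step seen on one core proved a poor guide to the step on the other: the same change on two cores in this assay, a number 9 percentage points higher (within the scatter) from compound 3 to compound 2 and a number 33 percentage points higher (beyond the scatter) from compound 1 to compound 4, 24 percentage points apart, beyond the scatter of two such steps This does not give a rule for other cores, since only two pairs are shown, and it does not tell which of the several differences between the two cores goes with the larger step, or why the step is larger there; each number also describes inhibition at a single concentration, so it is not a potency.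

The compounds shown leave open what other groups on that same aromatic carbon, such as bromo, methyl, methoxy or an amine, would do on either core, and whether inhibition would keep rising or fall back with such a group. They also leave open how chloro in place of fluoro would behave on a third core, which would show whether the large step is peculiar to the core of compound 1.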